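Three Compounds, One Open Lactam-Side Question

This account rests on a few compounds, and the source may have more. Where it says the series, first, only, none or still open, it means among the compounds named here.

Measured so far in an in vitro ADME assay on microsomes (Homo sapiens) for pharmacokinetics; a higher number here means faster removal of the compound, a lower number slower removal:
- compound 1 `CC(C)(C)C1CCNC(=O)C(N(Cc2ccc(C(=O)NC3CC3)cc2)S(=O)(=O)c2ccc(Cl)cc2)C1` gives 93 mL.min-1.g-1
- compound 2 `CC1(C)CCNC(=O)[C@H](N(Cc2ccc(C(=O)NC3CC3)cc2)S(=O)(=O)c2ccc(Cl)cc2)C1` gives 36 mL.min-1.g-1
- compound 3 `CC(C)C1CCNC(=O)C(N(Cc2ccc(C(=O)NC3CC3)cc2)S(=O)(=O)c2ccc(Cl)cc2)C1` gives 51 mL.min-1.g-1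

On these numbers, compound 3 cannot be told apart from either of the other two. The data show a 1.8-fold lower number from compound 1 to compound 3 (0.26 log units; within the scatter) and a 1.4-fold higher number from compound 2 to compound 3 (0.15 log units; within the scatter). Within the data shown here, only one measured step clears the scatter, namely a 2.6-fold lower number from compound 1 to compound 2 (0.41 log units; beyond the scatter).

The unmeasured compound 4 `CC1(C)CCNC(=O)C(N(Cc2ccc(C(=O)NC3CC3)cc2)S(=O)(=O)c2ccc(Cl)cc2)C1` differs from compound 3 in one place: 5,5-dimethyl-2-oxoazepan-3-yl in place of 5-isopropyl-2-oxoazepan-3-yl on a sulfonamide nitrogen. Here 5,5-dimethyl-2-oxoazepan-3-yl stands in place of 5-isopropyl-2-oxoazepan-3-yl on a sulfonamide nitrogen. Compound 2 carries the same group, but it is drawn with its stereocentre defined, whereas compound 4 leaves that centre undefined. The data do not show how the undefined form behaves, so this remains the main uncertainty.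

Among the measured compounds shown here, the closest guide is compound 2 at 36 mL.min-1.g-1, and the step that bears most directly on the change is the one already given between compound 2 and compound 3, read in reverse. No step beyond the scatter is therefore expected in this assay. The estimated step is a 1.3-fold lower number from compound 3 to compound 4 (0.13 log units; within the scatter). Compound 4 is estimated at 38 mL.min-1.g-1, with an expected range of 21 mL.min-1.g-1 to 68 mL.min-1.g-1.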

Compound 4, intrinsic clearance in microsomes: 45 mL.min-1.g-1
Beside the measured number, compound 4's estimate is 1.2-fold (0.07 log units) below it; the range from low to high includes it.
By their numbers in this assay, from the lowest: compounds 2, 4, 3 and 1 (each within the scatter of the next, the first and the last beyond it).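

In this assay, the 5,5-dimethyl-2-oxoazepan-3-yl and 5-isopropyl-2-oxoazepan-3-yl groups on the sulfonamide nitrogen cannot be told apart in this undefined form, with a 1.1-fold lower number from compound 3 to compound 4 (0.05 log units; within the scatter). Leaving the stereocentre undefined also gives no difference that can be read, with a 1.3-fold higher number from compound 2 to compound 4 (0.10 log units; within the scatter), and the comparison of compound 2 and compound 4 rests on a single feature: the fact that one of compounds 2 and 4 is drawn with a defined configuration and the other without, at the place where they differ. The step from the 2-oxo-5-(tert-butyl)azepan-3-yl group to the 5,5-dimethyl-2-oxoazepan-3-yl group now clears the scatter with the centre drawn or undefined, with a 2.1-fold lower number from compound 1 to compound 4 (0.32 log units; beyond the scatter) alongside a 2.6-fold lower number from compound 1 to compound 2 (0.41 log units; beyond the scatter), although a 1.8-fold lower number from compound 1 to compound 3 (0.26 log units; within the scatter) stays within it and so goes against any simple reading of the three groups as a series.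

The compounds shown leave open how the form drawn S behaves on its own, since the undefined compound 4 does not separate the two configurations. They also leave open where the plain 2-oxoazepan-3-yl group, or a ring carrying a hydroxyl group or a carboxylic acid in place of these carbon groups, would fall in this assay.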